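The source may report more compounds than this note shows. Statements on the series, on what has been measured and on what is new or still open speak of the compounds shown alone.

Working notes on the series. Three analogues on a shared core have been measured in a functional assay on PC-3 cells (Homo sapiens) for inhibition; on this read-out higher numbers stand for weaker inhibition and lower numbers for stronger inhibition. Compound 1 `Cc1c(C(=O)N/N=C\c2c(O)cccc2F)oc2cccc(O)c12` gives 8050 nM; compound 2 `Cc1c(C(=O)N/N=C\c2cccc(O)c2)oc2cccc(O)c12` gives 17600 nM; compound 3 `Cc1c(C(=O)N/N=C\c2ccccc2)oc2cccc(O)c12` gives 29200 nM. Compound 3 thus carries the highest number of the three, although its gap to compound 2 is within the scatter, a 1.7-fold higher number from compound 2 to compound 3 (0.22 log units; within the scatter), whereas the gap to compound 1 lies beyond it, a 3.6-fold higher number from compound 1 to compound 3 (0.56 log units; beyond the scatter).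

Compound 4 `Cc1c(C(=O)N/N=C\c2ccc(Br)cc2O)oc2cccc(O)c12` is not yet measured. It differs from compound 3 in one place: 4-bromo-2-hydroxyphenyl in place of phenyl on a carbon with a double bond to nitrogen. The measured steps that bear on this are the two that strip substituents from the same ring, a 3.6-fold higher number from compound 1 to compound 3 (0.56 log units; beyond the scatter) and a 1.7-fold higher number from compound 2 to compound 3 (0.22 log units; within the scatter). The change to compound 4 runs the other way, restoring a hydroxy and adding a bromine on that ring, so a lower number in this assay is expected, of a size between those two steps and most likely close to compound 1. The expected step is a 3.1-fold lower number from compound 3 to compound 4 (0.49 log units; beyond the scatter). Compound 4 is therefore estimated at 9500 nM, with a range from 4000 nM to 22000 nM.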

Compound 4, half-maximal inhibitory concentration: 2050 nM
Compound 4: middle estimate off by 4.6-fold (0.67 log units), on the high side; measured number below the stated range.
By their numbers in this assay, from the lowest: compound 4; then compound 1; then compounds 2 and 3 (each within the scatter of the next).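

In this assay, going by these compounds alone, the position on the carbon with a double bond to nitrogen proves far more responsive than the earlier compounds showed: 4-bromo-2-hydroxyphenyl in place of phenyl gives the largest step (a 14-fold lower number from compound 3 to compound 4 (1.15 log units; beyond the scatter)). The same group also outperforms both earlier hydroxy-bearing rings (an 8.6-fold lower number from compound 2 to compound 4 (0.93 log units; beyond the scatter); a 3.9-fold lower number from compound 1 to compound 4 (0.59 log units; beyond the scatter)), so a hydroxy group alone does not set the level here, and the substitution pattern on this ring matters. Compound 4 is now the strongest inhibitor of the four, though no supporting data account for this gain.

The compounds shown do not separate the share of the bromine from that of the hydroxy group, as none carries bromine without hydroxy. On these data alone, whether chlorine, a methoxy group or an amine could replace the bromine also remains open.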